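The source may report more compounds than this note shows. Statements on the series, on what has been measured and on what is new or still open speak of the compounds shown alone.

Measured in a functional assay on the whole organism (strain Wistar) for inhibition, with Rattus norvegicus as the target, read by paw edema, with stated times of 30 min and 5 h, at a dose of 0.05 mmol/kg by the oral route; on this read-out lower numbers stand for less inhibition and higher numbers for more inhibition at the one dose given (going by the name of the read-out):

Compound 1 `Cc1cc(O)ccc1C1=NN(c2ccc(S(C)(=O)=O)cc2)C(=O)CC1` gives 52.6%.
Compound 2 `CS(=O)(=O)c1ccc(N2N=C(c3ccc(-c4ccccc4)cc3)CCC2=O)cc1` gives 21%.
Compound 3 `CS(=O)(=O)c1ccc(N2N=C(c3ccc(Oc4ccccc4)cc3)CCC2=O)cc1` gives 65.7%.

Among these three numbers compound 1 stands second highest: compound 3 is nearest to it, and compound 2 furthest below it, both gaps beyond the scatter. Among the measured compounds shown here, the one step measured between neighbours is a number 44.7 percentage points higher from compound 2 to compound 3 (beyond the scatter), a change of the ring that hangs from the shared core.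

Compound 4 `CS(=O)(=O)c1ccc(N2N=C(c3ccc(Cl)c(Cl)c3)CCC2=O)cc1` differs from compound 1 in that same hanging ring: 3,4-dichlorophenyl in place of 4-hydroxy-2-methylphenyl on a carbon with a double bond to nitrogen. For the measured compounds named here, the measured step from compound 2 to compound 3 swaps one group for another at a different point of that ring, so it does not bear directly on a change from a hydroxy-bearing ring to a dichloro-bearing ring; the data give no step of this kind. What the three measured values show is that changes of this ring can move the read-out by large amounts in either direction.

Going by the values given here, with no directly comparable step, the expectation for compound 4 is a change of no more than modest size in this assay, namely a number 7.6 percentage points lower from compound 1 to compound 4 (within the scatter). Compound 4 is therefore estimated at 45%, with a range from 20% to 70%.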

Compound 4, a percentage reported as inhibition, in the whole organism at one dose (the size of the read-out at that dose, not a potency): 34.2%
The estimate for compound 4 lay 10.8 percentage points above the measured number; measured number inside the range.
By their numbers in this assay, from the lowest: compound 2; then compound 4; then compound 1; then compound 3.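

Exchanging the ring at this position, on the carbon with a double bond to nitrogen, gives a number 18.4 percentage points lower from compound 1 to compound 4 (beyond the scatter) in this assay, a change that removes the hydroxy and methyl groups and brings in two chlorines. The hydroxy-bearing ring does not simply give the highest number, however: compound 1 gives 52.6%, while compound 3, which has no hydroxy group, gives 65.7%. Nothing shown explains why this ring exchange lowers the number.

Since the hydroxy, methyl and chlorine groups all change in one step, the compounds shown cannot separate the part played by each. On these data alone, what a single chlorine, an amine or a carboxylic acid on this ring would do also remains open.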